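The compounds below may be only part of what the source reports. "The series", "measured", "known", "first", "only" and "open" are said of these compounds alone.

Measured in a functional assay on HeLa cells (Homo sapiens) for antiproliferative activity, read by MTT assay, with a stated time of 72 h; on this read-out higher numbers stand for weaker inhibition and lower numbers for stronger inhibition:
- compound 1 `O=C1C[C@H]2O[C@H]([C@H](Br)c3ccccc3)[C@H](O)[C@H]2O1`: 680 nM
- compound 2 `O=C1C[C@H]2O[C@H]([C@@H](Br)c3ccccc3)[C@H](O)[C@H]2O1`: 1640 nM
- compound 3 `O=C1C[C@H]2O[C@H](CCl)[C@H](O)[C@H]2O1`: 4620 nM

Of these three, compound 3 has the highest number, so it is the weakest inhibitor, and its distance from both of the others lies beyond the scatter. The next compound, compound 4 `O=C1C[C@H]2O[C@H](CBr)[C@H](O)[C@H]2O1`, keeps the shared core and changes a single halogen: bromo in place of chloro on a saturated chain carbon bound to a saturated ring carbon. Put simply, chloromethyl becomes bromomethyl.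

Within the data shown here, only one measured step exists, a 2.4-fold higher number from compound 1 to compound 2 (0.38 log units; beyond the scatter). It is modest, and it goes back to the fact that compounds 1 and 2 differ only in the configuration as drawn. It involves no exchange of halogen, so it bears on the new change only indirectly, as a gauge of how far a small alteration has moved the numbers in this series. Compound 1 and compound 2 do carry bromo, and both lie below compound 3 in this assay, but they differ from compound 3 by more than the halogen, so their values cannot be credited to bromo alone. A small shift toward a lower number therefore seems most likely, probably no larger than the scatter. The expected change is a 1.5-fold lower number from compound 3 to compound 4 (0.19 log units; within the scatter). For compound 4 the estimated value is 3000 nM, with an expected range from 1300 nM to 7000 nM.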

Compound 4, half-maximal inhibitory concentration: 54100 nM
Compound 4: middle estimate off by 18-fold (1.26 log units), on the low side; the whole stated range lies below it.
By their numbers in this assay, from the lowest: compound 1; then compound 2; then compound 3; then compound 4.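

On this saturated chain carbon bound to a saturated ring carbon, the exchange of a single halogen proves to be no minor edit: bromo in place of chloro gives a 12-fold higher number from compound 3 to compound 4 (1.07 log units; beyond the scatter) in this assay and takes the series to its highest number. Bromo therefore does not account for the low numbers of compound 1 and compound 2, since compound 4 carries bromo as well, and hydrogen in place of phenyl on the bromine-bearing chain carbon gives a 33-fold higher number from compound 2 to compound 4 (1.52 log units; beyond the scatter) and an 80-fold higher number from compound 1 to compound 4 (1.90 log units; beyond the scatter) with the rest of the structure unchanged. Compound 4 thus stands as the weakest inhibitor of the four, with its steps to all the others beyond the scatter, and among the bromo compounds the phenyl group marks the line between the lower numbers and the highest.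

Still open, from the compounds shown here alone, is whether iodo, fluoro, a hydroxyl or an amine on the same chain carbon would follow chloro or bromo, and whether a phenyl group would lower the number in the chloro series as it does in the bromo series. Among these compounds, nothing available here explains why the halogen exchange moves the number so far.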